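Adding a Trifluoromethyl Group Where Two Limits Give No Guide

A few compounds are considered here, and "the series" means these few. Any claim that something is new, unique, unknown or untested is made for them only; others in the source may bear on it.

Compound 2 `CC(C(=O)N1CCN(c2ccccc2)CC1)N1C(=O)CC(C)(C)C1=O` is the simpler of the two measured compounds. In a functional assay on the whole organism (strain Swiss) with Mus musculus as the target, in the maximal electroshock model, with a stated time of 0.25 h (on this read-out lower numbers stand for an effect already at smaller amounts and higher numbers for an effect only at larger amounts of compound), compound 2 gives > 130 mg/kg, which is a limit of the assay and not a number. Compound 1 `CC(C(=O)N1CCN(c2ccccc2C(F)(F)F)CC1)N1C(=O)CC(C)(C)C1=O` carries a trifluoromethyl group; in this assay compound 1 gives > 130 mg/kg, again a limit. The step that the two limits leave unreadable from compound 1 to compound 2 therefore cannot be read. Compound 3 `CC(C(=O)N1CCN(c2cccc(C(F)(F)F)c2)CC1)N1C(=O)CC(C)(C)C1=O` arises from compound 2 through (trifluoromethyl in place of hydrogen on an aromatic carbon). Because (the limit of > 130 mg/kg in this assay, at which 2 of the 2 values shown sit), no readable step bears on this change. The expected step that the limit leaves unreadable from compound 2 to compound 3 is estimated to stay within the scatter. Compound 3 is expected at 200 mg/kg, between 100 mg/kg and 500 mg/kg.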

Compound 3, dose for half-maximal effect: 114 mg/kg
Compound 3: middle estimate off by 1.8-fold (0.24 log units), on the high side, within the range that was stated.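

In this assay, going by these compounds alone, compound 3 gives the first readable number of the three, and trifluoromethyl meta to a large group yields an at least 1.1-fold lower number from compound 2 to compound 3 (0.05 log units; that floor lies within the scatter). On these data alone, that is only a floor, and the true size of the step stays unknown because one end of it is a limit: the limit of > 130 mg/kg in this assay, at which 2 of the 3 values shown sit. The step between compound 1 and compound 2 remains unreadable.

As far as these compounds go, compound 1 carries the same trifluoromethyl group at another place but stands only as a limit, so the role of position stays open. From the compounds shown here alone, how a chlorine atom, a nitrile or an amine at this place would read also stays open.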